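The source may hold more compounds than are shown below. What is called first, only, known or untested is meant among the compounds shown, and "the series" means these compounds.

Measured in a functional assay on MDA-MB-468 cells (Homo sapiens) for antiproliferative activity; a lower number here means a stronger inhibitor of growth, a higher number a weaker inhibitor of growth:
compound 1 `COc1ccc(-c2nc3cc(F)ccc3s2)cc1C` — 58 nM
compound 2 `Oc1ccc(-c2nc3cc(F)ccc3s2)cc1O` — 190 nM

Compound 2 gives the highest of the two numbers in this assay; compound 1 is the nearest, with a lower number, and that gap lies beyond the scatter. Compound 3 `COc1ccc(-c2nc3cc(F)ccc3s2)cc1O` differs from compound 2 by methyl in place of hydrogen on an oxygen on an aromatic ring. Among the measured compounds shown here, no measured step covers this change. Compound 1, which carries a methoxy, gives the lower number, so a modest downward move in this assay is expected for compound 3, likely not far beyond the scatter. The estimate for compound 3 is 100 nM (range 40 nM to 250 nM). This corresponds to an expected step of a 1.9-fold lower number from compound 2 to compound 3 (0.28 log units; within the scatter).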

Compound 3, concentration for 50% growth inhibition: 50 nM
The estimate for compound 3 lay 2.0-fold (0.30 log units) above the measured number; the range from low to high includes it.
By their numbers in this assay, from the lowest: compounds 3 and 1 (each within the scatter of the next); then compound 2.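

In this assay, methyl in place of hydrogen on this oxygen, hydroxy to methoxy, gives a 3.8-fold lower number from compound 2 to compound 3 (0.58 log units; beyond the scatter), so a hydrogen on this oxygen is not required for growth inhibition. With the methoxy kept, hydroxy in place of methyl on the aromatic carbon gives a 1.2-fold lower number from compound 1 to compound 3 (0.06 log units; within the scatter), so this assay does not separate those two groups. No evidence is at hand that bears on these steps.

Going by these compounds, whether an ethoxy or a longer chain on this oxygen keeps the number low remains open. So does the effect of an amine in place of the hydroxy on the aromatic carbon.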